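Methoxy on the phenyl of compound 2: an expected step

The source may report more compounds than this note shows. Statements on the series, on what has been measured and on what is new or still open speak of the compounds shown alone.

The series shares a chalcone-like core carrying a triazole with an alkyl chain, tested in a functional assay on SK-N-SH cells (Homo sapiens) for inhibition, read by MTT assay; on this read-out lower numbers stand for stronger inhibition and higher numbers for weaker inhibition. Compound 1 `O=C(CBr)Nc1ccc(C(=O)/C=C/c2cn(Cc3ccc(Br)cc3)nn2)cc1` gives 8300 nM. Compound 2 `CCCCCCCCCCn1cc(/C=C/C(=O)c2ccc(NC(=O)CN3CCN(c4ccccc4)CC3)cc2)nn1` gives 39500 nM, and compound 3 `CCCCCCCCn1cc(/C=C/C(=O)c2ccc(NC(=O)CN3CCN(c4ccccc4)CC3)cc2)nn1` gives 41400 nM. Among these three numbers compound 2 stands second highest; its nearest neighbour is compound 3, and the step of a 1.0-fold higher number from compound 2 to compound 3 (0.02 log units; within the scatter) lies within the scatter, while compound 1 sits furthest away with a clearly lower number.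

Compound 4 `CCCCCCCCCCn1cc(/C=C/C(=O)c2ccc(NC(=O)CN3CCN(c4ccccc4OC)CC3)cc2)nn1` differs from compound 2 in one place: methoxy in place of hydrogen on an aromatic carbon. None of the measured steps changes this part of the molecule; the only step shown, from compound 2 to compound 3, concerns the alkyl chain and is within the scatter, so nothing measured speaks to a methoxy on this ring. The phenyl bearing the change sits far from the chain that separates compound 2 and compound 3, and the data give no hint of how its substitution shifts the read-out.

The account therefore expects no step beyond the scatter, no change at the digits printed from compound 2 to compound 4 (within the scatter), for compound 4. The estimate for compound 4 in this assay is 39500 nM, within a range from 15000 nM to 100000 nM.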

Compound 4, half-maximal inhibitory concentration: 87600 nM
Estimate against measurement, compound 4: 2.2-fold (0.35 log units) below, and the stated range covers the measured number.
By their numbers in this assay, from the lowest: compound 1; then compounds 2 and 3 (each within the scatter of the next); then compound 4.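

The phenyl of the piperazine-bearing end turns out not to be indifferent to substitution: in this assay, methoxy in place of hydrogen on an aromatic carbon, ortho to a large group, gives a 2.2-fold higher number from compound 2 to compound 4 (0.35 log units; beyond the scatter), a modest move towards weaker inhibition but one beyond the scatter. The only earlier step between compounds differing in one place, a 1.0-fold higher number from compound 2 to compound 3 (0.02 log units; within the scatter), lay within the scatter and concerned the alkyl chain, so this is the first change shown that moves the read-out measurably in this part of the series. No measurement shown here gives a reason for the shift.

On these data alone, with a single substituent at a single position, the step cannot be said to belong to methoxy in particular rather than to any group on this carbon, and what a hydroxyl or a chlorine would do there remains open. Also open, as far as these compounds go, is whether methoxy on another carbon of this ring, or the same 2-methoxyphenyl paired with the chain of compound 3, would give a step of similar size.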